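Shortening the selenium chain in a quinazoline-free view of compound 1

The source may hold more compounds than are shown below. What is called first, only, known or untested is meant among the compounds shown, and "the series" means these compounds.

Compound 1 `CCCCC[Se]c1nc(NCc2ccc(SC)cc2)c2ccccc2n1` gives 65000 nM in a functional assay on MCF7 cells (Homo sapiens) for cytotoxicity, read by MTT assay, with a stated time of 72 h (on this read-out higher numbers stand for weaker inhibition of growth and lower numbers for stronger inhibition of growth), the second highest of three numbers. Compound 2 `CCCCC[Se]c1nc(NCc2ccccc2)c2ccccc2n1` gives 47100 nM and compound 3 `COc1ccc(CNc2nc(SC)nc3ccccc23)cc1` gives 85100 nM; all three sit within the scatter of one another. For the measured compounds named here, the one measured step, a 1.4-fold lower number from compound 1 to compound 2 (0.14 log units; within the scatter), concerns the benzylic ring rather than the selenium chain. Compound 4 `CSc1ccc(CNc2nc([Se]C)nc3ccccc23)cc1` differs from compound 1 by hydrogen in place of butyl on a saturated chain carbon bound to a selenium atom. Going by the values given here, no measured pair shows this change, and the steps seen so far are all small, so no step beyond the scatter is expected in this assay. For compound 4 the estimate is 65000 nM, between 30000 nM and 140000 nM, which means an expected step of no change at the digits printed from compound 1 to compound 4 (within the scatter).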

Compound 4, concentration for total growth inhibition: > 100000 nM
Compound 4: a limit, no number; the forecaster's own chance of this, stated with the estimate: 10%; middle value at least 1.5-fold (0.18 log units) away from the limit.
By their numbers in this assay, from the lowest: compounds 2, 1 and 3 (each within the scatter of the next). At a limit, above all of these: compound 4.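

In this assay compound 4 gives > 100000 nM, which is a limit and not a number. For the compounds shown here, the step, an at least 1.5-fold higher number from compound 1 to compound 4 (0.18 log units; that floor lies within the scatter), gives the first reading on the chain bound to selenium: pentyl to methyl brings no stronger inhibition of growth, but the floor of this step lies within the scatter, so its true size stays unfixed. Only one compound shown ends at such a limit: the limit of > 100000 nM in this assay, at which 1 of the 4 values shown sits.

Still open, on these data alone, is whether a propyl chain on the selenium atom, or a pentyl chain carrying an amine, would hold the number of compound 1.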